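The source may hold more compounds than are shown below. What is called first, only, known or untested is meant among the compounds shown, and "the series" means these compounds.

Three compounds, all sharing a sulfonamide joined through a saturated chain to an amine that carries a benzyl group, have been tested in a functional assay on MIA PaCa-2 cells (Homo sapiens) for inhibition, read by MTT assay, with a stated time of 72 h; a higher number here means a weaker inhibitor of growth, a lower number a stronger inhibitor of growth. Compound 1 `O=S(=O)(NCCCCNCc1ccc(Br)cc1)c1cc(C(F)(F)F)cc(C(F)(F)F)c1` gives 2100 nM there. Compound 2 `O=S(=O)(NCCCNCc1ccc(Cl)cc1)c1cc(C(F)(F)F)cc(C(F)(F)F)c1` gives 2800 nM in this assay, and compound 3 `O=S(=O)(NCCCCCCNCc1ccc(Br)cc1)c1ccc(C(F)(F)F)cc1` gives 3830 nM. Among the measured compounds shown here, the one single-point step among them, a 1.3-fold higher number from compound 1 to compound 2 (0.12 log units; within the scatter), is within the scatter. Compound 2 stands second highest of the three numbers, with compound 1 nearest and compound 3 furthest, and both gaps are within the scatter, so the three compounds cannot be told apart on these data.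

Compound 4 `O=S(=O)(NCCCNCC1COc2ccccc2O1)c1cc(C(F)(F)F)cc(C(F)(F)F)c1` is not yet measured. It differs from compound 2 by 2,3-dihydro-1,4-benzodioxin-2-yl in place of 4-chlorophenyl on a saturated chain carbon bound to an amine nitrogen. No measured step bears directly on this change: the only step shown swaps one halogen for another together with a shift in chain length, and it stayed within the scatter. There is therefore no basis for expecting a shift in a particular direction in this assay, and a step of no more than the scatter is expected, a 1.1-fold higher number from compound 2 to compound 4 (0.03 log units; within the scatter). Compound 4 is estimated at 3000 nM in this assay, with a range from 1200 nM to 8000 nM.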

Compound 4, concentration for 50% growth inhibition: 2600 nM
For compound 4 the middle estimate is 1.2-fold (0.06 log units) above the measured one, within the range that was stated.
By their numbers in this assay, from the lowest: compounds 1, 4, 2 and 3 (each within the scatter of the next).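

Within this assay, placing 2,3-dihydro-1,4-benzodioxin-2-yl in place of 4-chlorophenyl on a saturated chain carbon bound to an amine nitrogen gives a 1.1-fold lower number from compound 2 to compound 4 (0.03 log units; within the scatter) and leaves the read-out indistinguishable. Unlike the earlier step, which exchanged one halogen-bearing benzyl group for another while the chain also changed, this one keeps the chain fixed and replaces the group with a larger one that has no chlorine, adds a non-aromatic ring and brings in hydrogen-bond acceptors, so for these two compounds that whole change has no effect that can be read beyond the scatter. Nothing measured here explains why the two compounds read alike.

The compounds shown leave open whether an aromatic ring is needed at this place at all, as a cyclohexyl group or a morpholine ring in the same place is not among them. Among the compounds shown here, they also leave open whether the same exchange would read alike on the longer chain of compound 1, or on the sulfonamide with the single trifluoromethyl group of compound 3.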